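This account rests on a few compounds, and the source may have more. Where it says the series, first, only, none or still open, it means among the compounds named here.

Within the data shown here, in a functional assay on K562 cells (Homo sapiens) for inhibition, read by trypan blue exclusion, with a stated time of 72 h (on this read-out higher numbers stand for weaker inhibition and lower numbers for stronger inhibition), compound 2 (`Cn1c(=O)c(S(=O)(=O)c2ccc(F)cc2F)cc2cnc(Nc3ccccn3)nc21`) gives 35000 nM and stands highest of the two numbers so far, with compound 1 (`Cn1c(=O)c(S(=O)(=O)c2ccc(F)cc2F)cc2cnc(Nc3ccc4c(c3)CC(=O)N4)nc21`) at 15000 nM on the same scale. Compound 3 (`Cc1cc2cc(Nc3ncc4cc(S(=O)(=O)c5ccc(F)cc5F)c(=O)n(C)c4n3)ccc2[nH]1`), not yet measured, differs from compound 2 by 2-methyl-1H-indol-5-yl in place of pyridin-2-yl on a nitrogen on an aromatic ring and so carries 2-methyl-1H-indol-5-yl in place of pyridin-2-yl on a nitrogen on an aromatic ring. Among the measured compounds shown here, the only measured step that bears on this is the modest 2.3-fold higher number from compound 1 to compound 2 (0.37 log units; beyond the scatter) in which pyridin-2-yl also enters, there replacing a group with a five-membered ring and a six-membered ring. The incoming group has that pair of rings too, although its five-membered ring is aromatic, so this is only a loose guide. A modest move to a lower number is expected, with a 2.9-fold lower number from compound 2 to compound 3 (0.46 log units; beyond the scatter) as the estimated step in this assay for this change. Compound 3 is estimated at 12000 nM with an expected range from 3000 nM to 40000 nM.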

Compound 3, half-maximal inhibitory concentration: 750 nM
The estimate for compound 3 lay 16-fold (1.20 log units) above the measured number; the whole stated range lies above it.
By their numbers in this assay, from the lowest: compound 3; then compound 1; then compound 2.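

In this assay, the group on this nitrogen matters far more than the first pair suggested: the step of a 47-fold lower number from compound 2 to compound 3 (1.67 log units; beyond the scatter) is much larger than the earlier step of a 2.3-fold higher number from compound 1 to compound 2 (0.37 log units; beyond the scatter) in the opposite direction. Having a five-membered ring and a six-membered ring in this group is not enough in itself, since compound 1 also has such a pair, yet the step of a 20-fold lower number from compound 1 to compound 3 (1.30 log units; beyond the scatter) separates it from the 2-methyl-1H-indol-5-yl group, whose five-membered ring is aromatic. Nothing measured here gives a cause for these shifts.

The compounds shown do not separate the contribution of the methyl from that of the aromatic two-ring system. Whether a plain 1H-indol-5-yl group or a simple phenyl group would keep this gain remains an open question.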